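Trifluoromethyl in place of methoxy: the step to compound 4

This account rests on a few compounds, and the source may have more. Where it says the series, first, only, none or still open, it means among the compounds named here.

In an ADME assay on NPC-TW01 cells (Homo sapiens) for cytotoxicity, read by MTT assay (a lower number here means a stronger inhibitor, a higher number a weaker inhibitor), compound 1 (`O/N=C(\COc1cccc2ccccc12)c1ccccc1`) gives > 50000 nM, which is a limit of the assay. Compound 2 (`O/N=C(\COc1cccc2ccccc12)c1ccc(F)cc1`) gives > 50000 nM, also a limit. Among the measured compounds shown here, compound 3 (`COc1ccc(/C(COc2cccc3ccccc23)=N/O)cc1`), at 32300 nM, holds the only actual number in the set. Compound 4 (`O/N=C(\COc1cccc2ccccc12)c1ccc(C(F)(F)F)cc1`) has trifluoromethyl in place of methoxy on an aromatic carbon. Two measured steps introduce that methoxy: an at least 1.5-fold lower number from compound 1 to compound 3 (0.18 log units; that floor lies within the scatter) and an at least 1.5-fold lower number from compound 2 to compound 3 (0.18 log units; that floor lies within the scatter). Both floors lie within the scatter, while a step that the two limits leave unreadable from compound 1 to compound 2 cannot be read. Losing the methoxy of compound 3 is therefore expected to matter little in this assay, with no change beyond the scatter. The expected step is a 1.4-fold higher number from compound 3 to compound 4 (0.14 log units; within the scatter). Compound 4 is estimated at 45000 nM, within an expected range of 24000 nM to 70000 nM.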

Compound 4, half-maximal inhibitory concentration: 46400 nM
For compound 4 the middle estimate is 1.0-fold (0.01 log units) below the measured one; the measured number falls inside the stated range.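

In this assay, the step of a 1.4-fold higher number from compound 3 to compound 4 (0.16 log units; within the scatter) shows that a measurable number at this position, para to a large group, does not depend on methoxy, since trifluoromethyl also gives one. Against the other two compounds, only floors can be read: an at least 1.0-fold lower number from compound 2 to compound 4 (0.03 log units; that floor lies within the scatter) and an at least 1.0-fold lower number from compound 1 to compound 4 (0.03 log units; that floor lies within the scatter). These remain floors because compound 1 and compound 2 each sit at a limit: the limit of > 50000 nM in this assay, at which 2 of the 4 values shown sit.

From the compounds shown here alone, whether any group here can move the number beyond the scatter remains open. An amine or a carboxylic acid at this position would test that.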